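This account rests on a few compounds, and the source may have more. Where it says the series, first, only, none or still open, it means among the compounds named here.

Measured compounds:
- Compound 1 `CCS(=O)(=O)N(Cc1ccc(-c2cccc(F)c2)cc1)[C@@H](C)C(=O)N[C@H](C#N)CC(N)=O`: in an assay on isolated protein for inhibition of legumain (Homo sapiens), with stated times of 2 min and 60 min (a lower number here means a stronger inhibitor, a higher number a weaker inhibitor), compound 1 gives 3890 nM.
- Compound 2 `C[C@@H](C(=O)N[C@H](C#N)CC(N)=O)N(Cc1ccc(-c2cccc(F)c2F)cc1)S(=O)(=O)c1ccccc1`: in this assay compound 2 gives > 10000 nM, which is a limit of the assay and not a number.
- Compound 3 `C[C@@H](C(=O)N[C@H](C#N)CC(N)=O)N(Cc1ccc(-c2cccc(F)c2)cc1)S(=O)(=O)c1ccccc1`: in this assay compound 3 gives > 10000 nM, again a limit.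

Compound 2 therefore stands at the limit of this assay, where two of the three values shown sit (the limit of > 10000 nM in this assay, at which 2 of the 3 values shown sit); only compound 1 has a measured number.

Compound 4 `CCS(=O)(=O)N(Cc1ccc(-c2cccc(F)c2F)cc1)[C@@H](C)C(=O)N[C@H](C#N)CC(N)=O` differs from compound 2 by ethyl in place of phenyl on a sulfonyl sulfur. Among the measured compounds shown here, the one measured step that bears on this change is the same exchange read in the opposite direction: an at least 2.5-fold higher number from compound 1 to compound 3 (0.41 log units; beyond the scatter). Compound 2 is tied to that pair through a step that the two limits leave unreadable from compound 2 to compound 3, but with both of those values at the limit the size of that step cannot be read, so nothing is known about how the second fluoro shifts the number. Compound 4 is the difluoro counterpart of compound 1, and from compound 2 to compound 4 a move back below the limit is expected, roughly an at least 2.2-fold lower number from compound 2 to compound 4 (0.34 log units; beyond the scatter) in this assay, with compound 1 as the nearest anchor. Compound 4 is accordingly estimated at 4500 nM, with a range from 1800 nM to 15000 nM.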

Compound 4, half-maximal inhibitory concentration: 1090 nM
The estimate for compound 4 lay 4.1-fold (0.62 log units) above the measured number; the measured number lies below the stated range.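

In this assay, ethyl in place of phenyl on a sulfonyl sulfur now reads on a second core as an at least 9.1-fold lower number from compound 2 to compound 4 (0.96 log units; beyond the scatter), so the earlier single observation that the phenylsulfonyl compound sits on the weaker side is repeated in the same direction: the same change on two cores in this assay, an at least 2.5-fold higher number (0.41 log units; beyond the scatter) from compound 1 to compound 3 and an at least 9.1-fold higher number (0.96 log units; beyond the scatter) from compound 4 to compound 2; the limit leaves it open whether they differ
The exchange of fluoro in place of hydrogen on an aromatic carbon could not be read on the phenylsulfonyl side, and on the ethylsulfonyl side it becomes readable as a 3.6-fold lower number from compound 1 to compound 4 (0.55 log units; beyond the scatter). The ethylsulfonyl pair is thus the only one in the series that gives a number for the second fluoro, and that number points to a stronger inhibitor.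

The same fluoro step on the phenylsulfonyl side stays unreadable, and so does any difference in the size of the sulfonyl exchange between the two cores, as both phenylsulfonyl compounds sit at a limit of the assay: the limit of > 10000 nM in this assay, at which 2 of the 4 values shown sit.
Also open, going by these compounds, is how a group other than ethyl on the sulfonyl sulfur, such as methyl, a longer chain like n-propyl, or a dimethylamino group, would read in this assay.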